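A few compounds are considered here, and "the series" means these few. Any claim that something is new, unique, unknown or untested is made for them only; others in the source may bear on it.

Measured compounds:
Compound 1, `Oc1cccc(-c2cc(-c3ccncc3)nc(-c3ccccc3Cl)c2)c1`, "not determined" (no result reported) in an ADME assay on HEK293 cells (Homo sapiens) for cytotoxicity, read by CCK-8 assay and cell counting, with a stated time of 2 days; a lower number here means a stronger inhibitor, a higher number a weaker inhibitor.
Compound 2, `Oc1cccc(-c2cc(-c3ccc(Cl)cc3)nc(-c3cccnc3)c2)c1`, 39500 nM in this assay.

Going by the values given here, compound 2 is the only compound here with a number in this assay, so it stands alone and cannot be ranked against anything; compound 1 gives no value to compare with. Its number is high, which in this assay means a weak inhibitor of cell growth.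

Compound 3, `Oc1cccc(-c2cc(-c3ccncc3)nc(-c3ccc(Cl)cc3)c2)c1`, is not yet measured. It is built from the same atoms as compound 2, joined differently: pyridin-4-yl in place of pyridin-3-yl on an aromatic carbon. Among the compounds with values here, the only change is the point at which the pyridine ring nitrogen sits within that ring; the 3-hydroxyphenyl and 4-chlorophenyl groups on the shared core are untouched.

Within the data shown here, no step between two measured compounds is available to calibrate what such a swap does in this assay. A change of this size, one ring nitrogen moved by one position, is expected to give a step from compound 2 to compound 3 of about a 1.0-fold higher number from compound 2 to compound 3 (0.01 log units; within the scatter), which lies within the usual scatter, with no clear direction. Compound 3 is therefore estimated at 40000 nM in this assay, with a range of 15000 nM to 100000 nM.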

Compound 3, half-maximal inhibitory concentration: 2890 nM
Beside the measured number, compound 3's estimate is 14-fold (1.14 log units) above it; the whole stated range lies above it.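

In this assay, this position proves sensitive to where the ring nitrogen sits: pyridin-4-yl in place of pyridin-3-yl gives a 14-fold lower number from compound 2 to compound 3 (1.14 log units; beyond the scatter), a large step beyond the scatter. The two groups have the same heavy atoms and the same counts of hydrogen-bond donors and acceptors, and the 3-hydroxyphenyl and 4-chlorophenyl groups stay untouched, so moving the ring nitrogen is the only difference between these two compounds. Nothing measured here bears on what lies behind this step, so the data show only that it occurs and not how it arises.

On these data alone, compound 1 also carries pyridin-4-yl but has "not determined" (no result reported), so steps involving it cannot be read, and it remains unknown whether the place of the chlorine matters alongside this ring. Also open, as far as these compounds go, is whether the lower number needs a pyridine at all, a question that a plain phenyl ring, a pyrimidine ring or a pyridine bearing an amine on that same aromatic carbon could help to answer.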